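Amide variation on a shared core: tolerated concentrations

The source may hold more compounds than are shown below. What is called first, only, known or untested is meant among the compounds shown, and "the series" means these compounds.

Three amides on the shared core of compound 1 `COc1ccc(-c2cnc(NC(=O)CCc3ccccc3)n2C)cc1` have been tested in a toxicity assay on THP-1 cells (Homo sapiens) for inhibition; a higher number here means that more compound is tolerated, a lower number that less compound is tolerated. Compound 1 gives > 100000 nM in this assay, which is a limit of the assay rather than a number. Compound 2 `COc1ccc(-c2cnc(NC(=O)c3ccco3)n2C)cc1` likewise reaches only the limit > 100000 nM in this assay. Compound 3 `COc1ccc(-c2cnc(NC(=O)c3ccccc3)n2C)cc1` stands at the same limit, > 100000 nM in this assay. All three values sit at one point, (the limit of > 100000 nM in this assay, at which 3 of the 3 values shown sit), so the exchanges at the carbonyl carbon leave nothing readable: a step that the two limits leave unreadable from compound 1 to compound 2, a step that the two limits leave unreadable from compound 1 to compound 3 and a step that the two limits leave unreadable from compound 2 to compound 3.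

Compound 4 `COc1ccc(-c2cnc(NC(=O)C3CCOCC3)n2C)cc1` continues the series at the same position. oxan-4-yl in place of phenyl on a carbonyl carbon

Within the data shown here, no measured step gives a size; every comparison ends at the limit (the limit of > 100000 nM in this assay, at which 3 of the 3 values shown sit), and the exchange of phenethyl, furan-2-yl and phenyl among one another recorded nothing the assay could resolve. Compound 4 is expected to show a step that the limit leaves unreadable from compound 3 to compound 4, with the result most likely once more at the limit. The expected value for compound 4 in this assay is 150000 nM, within 60000 nM to 400000 nM.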

Compound 4, half-maximal cytotoxic concentration: > 100000 nM
Compound 4 gave a limit, no number (the forecaster's own chance of this, stated with the estimate: 85%); the middle value lies beyond the limit too.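

Compound 4 stands at a limit in this assay, as do compound 1, compound 2 and compound 3, so no step to compound 4 can be read: the limit of > 100000 nM in this assay, at which 4 of the 4 values shown sit.

The compounds shown leave open whether any exchange on the carbonyl carbon alters the tolerated concentration, and where the true values of these amides lie.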